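Notes on the step to compound 4

The source may hold more compounds than are shown below. What is called first, only, known or untested is meant among the compounds shown, and "the series" means these compounds.

Measured so far in a functional assay on MGC-803 cells (Homo sapiens) for antiproliferative activity, read by MTT assay, with a stated time of 72 h (a lower number here means a stronger inhibitor, a higher number a weaker inhibitor), for this series
compound 1 `CCCSc1nc(N/N=C(\C)c2ccc(O)cc2)c2nnn(Cc3ccccc3)c2n1` gives 16700 nM
compound 2 `CCCSc1nc(N/N=C/c2cccc(Cl)c2)c2nnn(Cc3ccccc3)c2n1` gives > 64000 nM as a limit of the assay
compound 3 `CCCSc1nc(N/N=C/c2ccc(N(C)C)cc2)c2nnn(Cc3ccccc3)c2n1` gives 13100 nM

Among the compounds with values here, compound 1 and compound 3 hold the only two actual numbers in this assay and lie within the scatter of each other. Compound 4 `CCCSc1nc(N/N=C/c2ccccc2F)c2nnn(Cc3ccccc3)c2n1` differs from compound 3 as follows: 2-fluorophenyl in place of 4-(dimethylamino)phenyl on a carbon with a double bond to nitrogen so that 2-fluorophenyl stands in place of 4-(dimethylamino)phenyl on a carbon with a double bond to nitrogen.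

The measured step closest to this change is an at least 4.8-fold lower number from compound 2 to compound 3 (0.68 log units; beyond the scatter) which swaps 3-chlorophenyl for the same 4-(dimethylamino)phenyl on that carbon. The step of an at least 3.8-fold higher number from compound 1 to compound 2 (0.58 log units; beyond the scatter) also ends at compound 2 and likewise gives only a bound on size. Within the data shown here, compound 4 shares with compound 2 a halogen-bearing phenyl, but no measured compound carries 2-fluorophenyl, so the comparison is loose. On the evidence of an at least 4.8-fold lower number from compound 2 to compound 3 (0.68 log units; beyond the scatter) the expected step is a 2.4-fold higher number from compound 3 to compound 4 (0.39 log units; beyond the scatter) and this is a move to a higher number, beyond the scatter but uncertain in size. For compound 4 the estimated value is 32000 nM with an expected range from 11000 nM to 80000 nM in this estimate.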

Compound 4, half-maximal inhibitory concentration: > 64000 nM
Compound 4 was reported as a limit; the forecaster's own chance of this, stated with the estimate: 35%; middle value at least 2.0-fold (0.30 log units) from the limit.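

In this assay, placing 2-fluorophenyl on the carbon with a double bond to nitrogen gives an at least 4.8-fold higher number from compound 3 to compound 4 (0.68 log units; beyond the scatter), and the comparison with the hydroxyphenyl compound gives an at least 3.8-fold higher number from compound 1 to compound 4 (0.58 log units; beyond the scatter). The halogen-bearing phenyl of compound 2 is therefore no longer a single case: with 2-fluorophenyl as well as 3-chlorophenyl, compound 2 and compound 4 stand apart from compound 1 and compound 3, and none of these compounds goes against that split, though the set is very small. Compound 4 stands at a limit, not a number, as does compound 2, so the step between them cannot be read and the two readable steps give only bounds: the limit of > 64000 nM in this assay, at which 2 of the 4 values shown sit.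

As far as these compounds go, how far compound 2 and compound 4 lie past that limit remains open, as does whether any halogen-bearing phenyl can give a measurable value. Also open, from the compounds shown here alone, is whether a primary amine, a piperidine or a carboxylic acid on the phenyl ring would keep a value like that of compound 3 at 13100 nM.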